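Methyl for trifluoromethyl on a thienopyridine amide series

This account rests on a few compounds, and the source may have more. Where it says the series, first, only, none or still open, it means among the compounds named here.

Measured compounds:
compound 1, `NC(=O)c1c(NC(=O)c2ccc(C(F)(F)F)cc2)sc2c1CCN(Cc1ccc(Cl)cc1Cl)C2`, 14900 nM
compound 2, `Cc1ccc(C(=O)Nc2sc3c(c2C(N)=O)CCN(Cc2ccc(Cl)cc2Cl)C3)cc1`, 19900 nM
compound 3, `Cc1ccccc1C(=O)Nc1sc2c(c1C(N)=O)CCN(C(=S)Nc1ccccc1C(F)(F)F)C2`, 23200 nM

In a functional assay on HL-60 cells (Homo sapiens) for antiproliferative activity, with a stated time of 24 h (a higher number here means a weaker inhibitor, a lower number a stronger inhibitor), compound 1 gives 14900 nM, and compound 2 gives 19900 nM. The difference between them is methyl in place of trifluoromethyl on an aromatic carbon, and it made a step of a 1.3-fold higher number from compound 1 to compound 2 (0.13 log units; within the scatter). Compound 3, with a different core, gives 23200 nM in this assay; the difference between the cores of compound 1 and compound 3 is not broken down here. Compound 4, `Cc1ccccc1NC(=S)N1CCc2c(sc(NC(=O)c3ccccc3C)c2C(N)=O)C1`, has not yet been measured. It differs from compound 3 by methyl in place of trifluoromethyl on an aromatic carbon. Going by the values given here, this is the same kind of change as the one from compound 1 to compound 2, though the place differs: para to a large group in the first pair, ortho to a large group in the second. Since the earlier step was within the scatter, a step of about a 1.2-fold higher number from compound 3 to compound 4 (0.08 log units; within the scatter) is expected here too, resting on a 1.3-fold higher number from compound 1 to compound 2 (0.13 log units; within the scatter) alone. For compound 4 the estimate in this assay is 28000 nM, within 12000 nM to 60000 nM.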

Compound 4, half-maximal inhibitory concentration: > 50000 nM
Compound 4: only a limit was reported; the forecaster's own chance of this, stated with the estimate: 15%; middle value at least 1.7-fold (0.25 log units) away from the limit.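

In this assay compound 4 gives > 50000 nM, which is a limit of the assay and not a number. Putting methyl in place of trifluoromethyl on an aromatic carbon, ortho to a large group, makes an at least 2.1-fold higher number from compound 3 to compound 4 (0.33 log units; beyond the scatter), so on this core the change does lead to a higher number, whereas the step on the other core stays within the scatter. This does not show that the change behaves differently from one core to the other, nor that it carries over unaltered, as only one pair per core is available and one of the two steps is known only as a limit: the same change on two cores in this assay, a 1.3-fold higher number (0.13 log units; within the scatter) from compound 1 to compound 2 and an at least 2.1-fold higher number (0.33 log units; beyond the scatter) from compound 3 to compound 4; the limit leaves it open whether they differ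

The compounds shown leave open how far the step from compound 3 really extends and whether the two cores would part once a full value is in hand. They also leave open how a chlorine, a methoxy group or a nitrile on the same aromatic carbon would compare with methyl and trifluoromethyl on either core.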